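Swapping Chloro for Methoxymethyl on a Shared Core

The source may hold more compounds than are shown below. What is called first, only, known or untested is meant among the compounds shown, and "the series" means these compounds.

Among the measured compounds shown here, compound 2 `Nc1ccc(-c2cc(=O)c3c(N)c(F)c(Cl)c(F)c3o2)cc1F` is the only member of this small set that gives a number in a functional assay on MCF7 cells (Homo sapiens) for cytotoxicity, read by neutral red uptake, with a stated time of 3 days; on this read-out lower numbers stand for stronger inhibition and higher numbers for weaker inhibition; there compound 2 gives 210 nM. Compound 1 `Nc1ccc(-c2cc(=O)c3c(N)c(F)c(O)c(F)c3o2)cc1F` reaches only a limit of this assay, giving > 10000 nM. Compound 3 `CCCCCCCCCCCCCCCCCC(=O)OCc1c(F)c(N)c2c(=O)cc(-c3ccc(N)c(F)c3)oc2c1F` likewise reaches only a limit, giving > 10000 nM. Thus two of the three results sit at the limit of > 10000 nM in this assay, at which 2 of the 3 values shown sit, and the picture of this position rests on one step: an at least 47-fold lower number from compound 1 to compound 2 (1.67 log units; beyond the scatter), a large shift toward stronger inhibition when chloro replaces hydroxy.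

The change now followed leads to compound 4 `COCc1c(F)c(N)c2c(=O)cc(-c3ccc(N)c(F)c3)oc2c1F`: methoxymethyl in place of chloro on an aromatic carbon. For the measured compounds named here, no measured step exchanges chloro for methoxymethyl, so the step from compound 1 to compound 2 bears on it only as a sign that the chloro at this place is tied to the sole strong result; both other groups at this place ended at a limit. A step toward weaker inhibition is therefore expected, a 14-fold higher number from compound 2 to compound 4 (1.15 log units; beyond the scatter), with a fair chance of another limit. For compound 4 the estimate is 3000 nM, between 500 nM and 10000 nM.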

Compound 4, half-maximal inhibitory concentration: 46 nM
Beside the measured number, compound 4's estimate is 65-fold (1.81 log units) above it; the whole stated range lies above it.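

In this assay, among the compounds shown here, chloro proves not to be the only group at this place that goes with strong inhibition: exchanging it for methoxymethyl gives a 4.6-fold lower number from compound 2 to compound 4 (0.66 log units; beyond the scatter). The strongest result shown therefore no longer belongs to chloro, and the exchange of hydroxy for methoxymethyl gives an at least 210-fold lower number from compound 1 to compound 4 (2.33 log units; beyond the scatter). Weak results remain at this place, as compound 1 and compound 3 each stop at a limit of the assay: the limit of > 10000 nM in this assay, at which 2 of the 4 values shown sit.

The compounds shown leave open whether the ether oxygen or the added carbon atoms of methoxymethyl go with the lower number, since neither hydroxymethyl, ethyl nor ethoxymethyl stands at this place among them. They also leave open how an amine or a carboxylic acid at this place would read, and whether the order seen here holds in any other cells.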